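Sulfonyl aryl variation and liver microsome clearance

The source may hold more compounds than are shown below. What is called first, only, known or untested is meant among the compounds shown, and "the series" means these compounds.

Compound 3 `COc1ccc(-c2c(S(=O)(=O)c3ccc(C)c(C)c3)cnc3cc(F)ccc23)cc1` carries a 3,4-dimethylphenyl group on the sulfonyl sulfur. In an ADME assay on microsomes from liver (Homo sapiens) for metabolic stability, tested at 2.5 uM (on this read-out higher numbers stand for fast clearance and lower numbers for slow clearance), compound 3 gives 4.13 mL/min, the highest number among the three measured compounds. Compound 2 `COc1ccc(-c2c(S(=O)(=O)c3cccc(F)c3)cnc3cc(F)ccc23)cc1` gives 1.89 mL/min in this assay, and compound 1 `COc1ccc(-c2c(S(=O)(=O)c3cccc(C#N)c3)cnc3cc(F)ccc23)cc1` gives 0.92 mL/min.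

The step of a 2.1-fold higher number from compound 1 to compound 2 (0.31 log units; beyond the scatter) accompanies the change of cyano to fluoro on the aromatic carbon. The step of a 4.5-fold higher number from compound 1 to compound 3 (0.65 log units; beyond the scatter) and the step of a 2.2-fold higher number from compound 2 to compound 3 (0.34 log units; beyond the scatter) both end at the 3,4-dimethylphenyl compound, each beyond the scatter, so the two measured changes that reach compound 3 both went upward.

Compound 4 `COc1ccc(-c2c(S(=O)(=O)c3ccc(F)c(Cl)c3)cnc3cc(F)ccc23)cc1` differs from compound 3 by 3-chloro-4-fluorophenyl in place of 3,4-dimethylphenyl on a sulfonyl sulfur. The change runs from the 3,4-dimethylphenyl group toward a halogenated phenyl, the same direction as the reverse of the step from compound 2 to compound 3, in which compound 2 sits at 1.89 mL/min. Going by the values given here, no measured pair covers a chloro-fluoro combination, so the estimate leans on compound 2 alone.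

For compound 4 the expectation in this assay is therefore a lower number than compound 3, with a step of about a 2.1-fold lower number from compound 3 to compound 4 (0.31 log units; beyond the scatter). The estimated value for compound 4 is 2 mL/min, within a range from 1 mL/min to 4 mL/min.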

Compound 4, intrinsic clearance in a liver preparation (reported as CLH), per the amount of preparation that the assay uses: 1.08 mL/min
Compound 4: middle estimate off by 1.9-fold (0.27 log units), on the high side, within the range that was stated.
By their numbers in this assay, from the lowest: compounds 1, 4 and 2 (each within the scatter of the next, the first and the last beyond it); then compound 3.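

Replacing 3,4-dimethylphenyl with 3-chloro-4-fluorophenyl on the sulfonyl sulfur gives a 3.8-fold lower number from compound 3 to compound 4 (0.58 log units; beyond the scatter) in this assay, and both groups are printed with the same heavy-atom count and no hydrogen-bond donors or acceptors, so this step isolates methyl against halogen substituents on the ring. Going by these compounds alone, the new group does not separate from the other two aryl groups, with a 1.8-fold lower number from compound 2 to compound 4 (0.24 log units; within the scatter) and a 1.2-fold higher number from compound 1 to compound 4 (0.07 log units; within the scatter) in the same assay, which leaves compound 3 as the only compound with steps beyond the scatter to all three others, while compound 1 and compound 2 remain beyond the scatter of each other. No measurement in hand accounts for the gap between the dimethyl compound and the three compounds carrying halogen or nitrile substituents.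

Still open, as far as these compounds go, is whether a single methyl group on the sulfonyl aryl ring is enough to reach the level of compound 3, or whether both methyl groups are needed. Also open is how this assay would read with an amine or a carboxylic acid on that ring, since every aryl group shown carries only methyl, halogen or nitrile substituents.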